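Selenium-to-sulfur swap on a bis-furoyl isoselenourea core

This account rests on a few compounds, and the source may have more. Where it says the series, first, only, none or still open, it means among the compounds named here.

The series rests on two cores. Compound 1 `C[Se]/C(=N\C(=O)c1cc2ccccc2s1)NC(=O)c1cc2ccccc2s1` carries a methylselanyl group on a carbon with a double bond to nitrogen, and in a functional assay on K562 cells (Homo sapiens) for cytotoxicity, read by MTT assay, with a stated time of 72 h (on this read-out lower numbers stand for higher toxicity in this test and higher numbers for lower toxicity in this test), compound 1 gives 89600 nM. Compound 3 `CS/C(=N\C(=O)c1cc2ccccc2s1)NC(=O)c1cc2ccccc2s1` is its sulfur counterpart, and in this assay compound 3 gives 98600 nM. The change between them is a group of 2 heavy atoms (1 carbon, 1 sulfur; no ring) in place of a group of 2 heavy atoms (1 carbon, 1 selenium; no ring), on a carbon with a double bond to nitrogen and it moved the read-out by a 1.1-fold higher number from compound 1 to compound 3 (0.04 log units; within the scatter).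

Compound 2 `C[Se]/C(=N\C(=O)c1ccco1)NC(=O)c1ccco1` belongs to the second core; how the two cores differ is not broken down here. In this assay compound 2 reaches only a limit of the assay, > 100000 nM, and that value sits at the limit of > 100000 nM in this assay, at which 1 of the 3 values shown sits.

Compound 4 `CS/C(=N\C(=O)c1ccco1)NC(=O)c1ccco1` is not yet measured in this assay. It differs from compound 2 by a group of 2 heavy atoms (1 carbon, 1 sulfur; no ring) in place of a group of 2 heavy atoms (1 carbon, 1 selenium; no ring), on a carbon with a double bond to nitrogen and this is the same change as that from compound 1 to compound 3, at the same place. Since that change gave only a 1.1-fold higher number from compound 1 to compound 3 (0.04 log units; within the scatter), a step of similar size is expected here, namely a step that the limit leaves unreadable from compound 2 to compound 4, with the reservation that the starting point is itself a limit. On that basis compound 4 is expected to give about 110000 nM in this assay, between 55000 nM and 250000 nM, and it is estimated likely that the assay will again report only a limit for compound 4.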

Compound 4, concentration lethal to 50% of the cells: > 100000 nM
Compound 4 was reported as a limit (the forecaster's own chance of this, stated with the estimate: 70%); the middle value lies beyond the limit too.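

No step can be read between compound 2 and compound 4 in this assay, since both compounds are reported only at the same limit of the assay: the limit of > 100000 nM in this assay, at which 2 of the 4 values shown sit.

The compounds shown leave open how far beyond that limit compound 2 and compound 4 lie, and whether the change from selenium to sulfur on the core of compound 2 alters the read-out at all.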